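Moving the bromine on a shared core

This account rests on a few compounds, and the source may have more. Where it says the series, first, only, none or still open, it means among the compounds named here.

Compound 1 `COc1ccc(/C=C2\CCC/C(=C\c3ccc(Cl)cc3)C2=O)cc1OC` gives 6300 nM
Compound 2 `COc1ccc(/C=C2\CCC/C(=C\c3cccc(Br)c3)C2=O)cc1OC` gives 5300 nM

Both numbers come from a functional assay on MCF7 cells (Homo sapiens) for cytotoxicity, read by MTT assay, with a stated time of 72 h (a lower number here means a stronger inhibitor, a higher number a weaker inhibitor), and they do not separate. The measured step is a 1.2-fold lower number from compound 1 to compound 2 (0.08 log units; within the scatter), so compound 2 stands level with compound 1 and neither can be called the stronger.

Compound 3 `COc1ccc(/C=C2\CCC/C(=C\c3ccc(Br)cc3)C2=O)cc1OC` has not yet been measured. It keeps the shared core and differs from compound 2 in one place, on a double-bonded chain carbon bound to a double-bonded ring carbon: 4-bromophenyl in place of 3-bromophenyl on a double-bonded chain carbon bound to a double-bonded ring carbon is the whole change. Among the compounds with values here, only one measured step bears on this, and it is an imperfect guide, since it exchanges 4-chlorophenyl for 3-bromophenyl and not one bromophenyl group for the other. That step, a 1.2-fold lower number from compound 1 to compound 2 (0.08 log units; within the scatter), stayed within the scatter, so no change beyond the scatter is expected, in either direction. The expected step is a 1.1-fold higher number from compound 2 to compound 3 (0.04 log units; within the scatter) and it remains an estimate. In this assay the estimate for compound 3 is 5800 nM, expected to fall between 3000 nM and 11000 nM.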

Compound 3, half-maximal inhibitory concentration: 6900 nM
The estimate for compound 3 lay 1.2-fold (0.08 log units) below the measured number; the range from low to high includes it.
By their numbers in this assay, from the lowest: compounds 2, 1 and 3 (each within the scatter of the next).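

In this assay, 4-bromophenyl in place of 3-bromophenyl gives a 1.3-fold higher number from compound 2 to compound 3 (0.11 log units; within the scatter), so at this place, on a double-bonded chain carbon bound to a double-bonded ring carbon, the two bromophenyl groups do not separate. Within the data shown here, compound 3 also isolates the halogen for the first time: the earlier step exchanged 4-chlorophenyl for 3-bromophenyl and so changed two things at once, whereas bromo in place of chloro on an aromatic carbon gives a 1.1-fold higher number from compound 1 to compound 3 (0.04 log units; within the scatter) and these two compounds do not separate either. Taken together, the three compounds stand level, and neither the identity of the halogen nor the bromine's place in the two bromophenyl groups shows any effect beyond the scatter in this assay, while nothing shown offers a reason for that level standing.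

From the compounds shown here alone, all three compounds carry a single halogen on this phenyl ring, so it remains open whether an amine, a hydroxyl or a carboxylic acid there would stay level with them or move the number beyond the scatter. Going by these compounds, it also remains open whether the level standing of these three compounds would hold on cells other than those used here.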